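The source may hold more compounds than are shown below. What is called first, only, known or untested is meant among the compounds shown, and "the series" means these compounds.

Compound 2 `Cn1cnnc1SCC(=O)Nc1ccc(-c2nc(-c3ccccc3)c(-c3ccccc3)n2C)cc1` gives 3.2 ug/mL in a functional assay on MCF7 cells (Homo sapiens) for cytotoxicity, read by MTT assay, with a stated time of 24 h (a lower number here means a stronger inhibitor, a higher number a weaker inhibitor), the lowest of the two numbers recorded. Among the compounds with values here, compound 1 `Cn1c(-c2ccc(NC(=O)CSc3nc4ccccc4s3)cc2)nc(-c2ccccc2)c1-c1ccccc1` gives 15.8 ug/mL, and the single measured step, a 4.9-fold lower number from compound 1 to compound 2 (0.69 log units; beyond the scatter), came from replacing a fused bicyclic group on the sulfur with a small five-membered ring. Compound 3 `Cn1nnnc1SCC(=O)Nc1ccc(-c2nc(-c3ccccc3)c(-c3ccccc3)n2C)cc1` differs from compound 2 by 1-methyl-1H-tetrazol-5-yl in place of 4-methyl-4H-1,2,4-triazol-3-yl on a sulfur. Here one small five-membered aromatic ring replaces another of the same size, a far milder exchange than the one that produced the measured step, so no step beyond the scatter is expected in this assay. Compound 3 is therefore estimated at 3.2 ug/mL, between 1.5 ug/mL and 7 ug/mL, a step of no change at the digits printed from compound 2 to compound 3 (within the scatter).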

Compound 3, half-maximal inhibitory concentration: 4.5 ug/mL
For compound 3 the middle estimate is 1.4-fold (0.15 log units) below the measured one; measured number inside the range.
By their numbers in this assay, from the lowest: compounds 2 and 3 (each within the scatter of the next); then compound 1.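

In this assay, exchanging one small five-membered aromatic ring on the sulfur for another, with 1-methyl-1H-tetrazol-5-yl entering, stays within the scatter (a 1.4-fold higher number from compound 2 to compound 3 (0.15 log units; within the scatter)). The 1-methyl-1H-tetrazol-5-yl group also stands clear of 1,3-benzothiazol-2-yl (a 3.5-fold lower number from compound 1 to compound 3 (0.55 log units; beyond the scatter)), so the earlier gain is not confined to the triazole. No measured evidence accounts for either step. Still open, on these data alone, is how a simple amine or a carboxylic acid would fare in place of the ring on the sulfur, and whether a six-membered ring such as pyridine would hold this level.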